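A Dimethylamino Swap in a Growth Inhibitor Series

The source may report more compounds than this note shows. Statements on the series, on what has been measured and on what is new or still open speak of the compounds shown alone.

Among the compounds with values here, only two compounds have been measured so far in a functional assay on DU-145 cells (Homo sapiens) for inhibition, read by trypan blue exclusion, with a stated time of 96 h (a higher number here means a weaker inhibitor of growth, a lower number a stronger inhibitor of growth), and they give the same reading. Compound 1 (`O=C(/C(=C\c1ccc(O)c([N+](=O)[O-])c1)SCc1ccc(Br)cc1)c1ccc(Br)cc1`) gives 10000 nM there and compound 2 (`Cc1cc(C)cc(/C=C(\C(=O)c2ccc(Br)cc2)S(=O)(=O)Cc2ccc(F)cc2)c1`) gives 10000 nM too, so compound 2 stands level with compound 1.

Compound 3 (`CN(C)c1ccc(/C=C(\C(=O)c2ccc(Br)cc2)S(=O)(=O)Cc2ccc(F)cc2)cc1`) differs from compound 2 in one place. It carries 4-(dimethylamino)phenyl in place of 3,5-dimethylphenyl on a double-bonded chain carbon bound to a double-bonded chain carbon.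

Within the data shown here, no measured pair yet differs in one place only, so nothing shows how large a single change can be. Any forecast therefore rests on one anchor, compound 2 at 10000 nM in this assay and on the structural change itself. A modest move towards stronger growth inhibition is expected, with an estimated 2.5-fold lower number from compound 2 to compound 3 (0.40 log units; beyond the scatter) as the size of the step, although a result within the scatter would fit as well. For compound 3 the expected value is 4000 nM with a range from 800 nM to 15000 nM as an estimate.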

Compound 3, concentration for 50% growth inhibition: 50000 nM
For compound 3 the middle estimate is 13-fold (1.10 log units) below the measured one; the measured number lies above the stated range.
By their numbers in this assay, from the lowest: compounds 1 and 2 (each within the scatter of the next); then compound 3.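

In this assay, putting 4-(dimethylamino)phenyl in place of 3,5-dimethylphenyl on a double-bonded chain carbon bound to a double-bonded chain carbon gives a 5.0-fold higher number from compound 2 to compound 3 (0.70 log units; beyond the scatter), a shift towards weaker growth inhibition. Within the data shown here, this is the first single change whose size can be read, since the earlier compounds offered no pair differing in one place only, and it shows that the reading responds to the group held at this position. No measurement here bears on the reason for this step.

Because this one swap removes 3,5-dimethylphenyl and brings in 4-(dimethylamino)phenyl together, the compounds shown cannot separate the loss of the two methyl groups from the arrival of the dimethylamino group. As far as these compounds go, it also remains open how the reading would respond at this same place to a plain phenyl ring, or to a phenyl ring carrying a methoxy group or a carboxylic acid, and whether any group there could move the number towards stronger growth inhibition.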